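Swapping the Aryl Amide Cap in an Antiproliferative Hydroxamate Series

This account rests on a few compounds, and the source may have more. Where it says the series, first, only, none or still open, it means among the compounds named here.

Compound 2 `CN(C)c1ccc(C(=O)NC(CCCCCC(=O)NO)C(=O)NCc2ccccc2)cc1` gives the lowest number of the three measured in a functional assay on NFF cells (Homo sapiens) for antiproliferative activity (on this read-out lower numbers stand for stronger inhibition and higher numbers for weaker inhibition), namely 870 nM. Compound 1 `CN(C)c1ccc(C(=O)N[C@H](CCCCCC(=O)NO)C(=O)NCc2ccccc2)cc1` gives 1000 nM, and the step of a 1.1-fold lower number from compound 1 to compound 2 (0.06 log units; within the scatter) is consistent with the fact that one of compounds 1 and 2 is drawn with a defined configuration and the other without, at the place where they differ. Compound 3 `CN(C)c1ccc(C(=O)NC(CCCCCC(=O)NO)C(=O)NC2CCCc3ccccc32)cc1` gives 1810 nM, so that a 2.1-fold higher number from compound 2 to compound 3 (0.32 log units; beyond the scatter) amounts to a modest loss. Compound 4 `O=C(CCCCCC(NC(=O)c1ccco1)C(=O)NCc1ccccc1)NO` differs from compound 2 by furan-2-yl in place of 4-(dimethylamino)phenyl on a carbonyl carbon. Neither measured step touches the carbonyl carbon where this change sits, so the measured steps give no direct guide; the change is therefore expected to bring no step beyond the scatter. The expected step in this assay is a 1.4-fold higher number from compound 2 to compound 4 (0.14 log units; within the scatter). Compound 4 is accordingly estimated at 1200 nM, with a range of 400 nM to 3500 nM.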

Compound 4, half-maximal inhibitory concentration: 4600 nM
Compound 4: the middle estimate sits 3.8-fold (0.58 log units) below what was measured; measured number outside the range, above it.
By their numbers in this assay, from the lowest: compounds 2, 1 and 3 (each within the scatter of the next, the first and the last beyond it); then compound 4.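

In this assay, furan-2-yl in place of 4-(dimethylamino)phenyl on the carbonyl carbon brings a 5.3-fold higher number from compound 2 to compound 4 (0.72 log units; beyond the scatter). The earlier steps shown here left this place untouched, and this one shows that the group here is not interchangeable, with the change costing activity beyond the scatter. Nothing in the available evidence bears on the reason for this step. The compounds shown leave open whether the loss goes with the change of ring or with the absence of the dimethylamino group; a plain phenyl at this place would separate the two.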